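Carbamoylmethyl for triazole on the shared core

The source may hold more compounds than are shown below. What is called first, only, known or untested is meant among the compounds shown, and "the series" means these compounds.

Compound 2 `CC(C)C(c1nnc[nH]1)c1ccc(-c2ccc3cccc(F)c3c2)[nH]c1=O` was tested in an ADME assay on microsomes from liver (Mus musculus) for metabolic stability (on this read-out higher numbers stand for a longer-lived compound and lower numbers for a shorter-lived compound), and gives 0.213 h. For the measured compounds named here, compound 1 `CC(C)C(c1ccc(-c2ccc3cccc(F)c3c2)[nH]c1=O)N1CCN/C1=N\C#N` in this assay gives 0.207 h, and the two values sit within the scatter of each other, so compound 2 stands apart from nothing measured so far. Going by the values given here, the only measured step, a 1.0-fold higher number from compound 1 to compound 2 (0.01 log units; within the scatter), shows that a sizeable change at the saturated chain carbon bound to an aromatic carbon and a saturated chain carbon left the half-life unmoved. Compound 3 `CC(C)C(CC(N)=O)c1ccc(-c2ccc3cccc(F)c3c2)[nH]c1=O` alters the same position again: carbamoylmethyl in place of 4H-1,2,4-triazol-3-yl on a saturated chain carbon bound to an aromatic carbon and a saturated chain carbon. Among the compounds with values here, that earlier step is the only guide, and it bears only loosely, since neither group of compound 3 has been measured. The half-life of compound 3 is therefore expected to stay close to that of compound 2, with the step of a 1.0-fold higher number from compound 2 to compound 3 (0.01 log units; within the scatter) estimated to lie within the scatter. The estimate for compound 3 is 0.22 h, with a range from 0.1 h to 0.5 h.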

Compound 3, half-life: < 0.0667 h
Compound 3: only a limit was reported; the forecaster's own chance of this, stated with the estimate: 5%; at least 3.2-fold (0.51 log units) between middle value and limit.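

Compound 3 is reported in this assay only as a limit, not as a number: the limit of < 0.0667 h in this assay, at which 1 of the 3 values shown sits.

Even so, the position on a saturated chain carbon bound to an aromatic carbon and a saturated chain carbon proves sensitive to the group it carries: carbamoylmethyl in place of 4H-1,2,4-triazol-3-yl gives an at least 3.1-fold lower number from compound 2 to compound 3 (0.50 log units; beyond the scatter), and the comparison with the ring of compound 1 gives an at least 3.1-fold lower number from compound 1 to compound 3 (0.49 log units; beyond the scatter). The earlier step, a 1.0-fold higher number from compound 1 to compound 2 (0.01 log units; within the scatter), had shown only two ring-bearing groups that could not be told apart, whereas carbamoylmethyl, which has no ring, is the first group shown to separate from them.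

The limit leaves the full size of both steps unknown. The compounds shown also leave open whether a carboxylic acid on the same chain, or a longer chain ending in the same amide, would stay with compound 2 or fall with compound 3.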